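This account rests on a few compounds, and the source may have more. Where it says the series, first, only, none or still open, it means among the compounds named here.

Measured compounds:

Compound 1, `O=C(O)CCCc1cn(CC(=O)O)c2c(/C=C/c3ccc(OCCCCc4c(F)ccc(F)c4F)cc3)cccc12`: 45%
Compound 2, `Cc1c(Cl)cccc1CCCCOc1ccc(C#Cc2ccc(F)c3c(CCCC(=O)O)c(C)n(CCCC(=O)O)c23)cc1`: 99%
Compound 3, `Cc1c(CCCC(=O)O)c2cccc(/C=C/c3ccc(OCCCCc4c(F)c(F)cc(F)c4F)cc3)c2n1CC(=O)O`: 9%

These three compounds were tested in a functional assay on the whole organism for inhibition, with Cavia porcellus as the target, with stated times of 1 h and 10 min, at a dose of 0.3 mg/kg by the oral route; a higher number here means a stronger effect of the compound at the dose given, a lower number a weaker effect. Compound 2 gives the highest reading at 99%, and compound 1 sits in the middle with 45%. Compound 3 stands lowest of the three numbers at 9%; its nearest neighbour is compound 1, whose number lies beyond the scatter above it, and compound 2 lies further still above it.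

The step followed here leads from compound 3 to compound 4, `Cc1c(CCCC(=O)O)c2cccc(/C=C/c3ccc(OCCCCc4cc(F)c(F)c(F)c4F)cc3)c2n1CC(=O)O`, which has not yet been measured in this assay. The two compounds hold the same atoms, joined differently: 2,3,4,5-tetrafluorophenyl in place of 2,3,5,6-tetrafluorophenyl on a saturated chain carbon, four bonds along the chain from an oxygen on an aromatic ring. Only the pattern of the four fluorine atoms on that outer ring moves, while the shared core and every other part stay as they are.

For the measured compounds named here, no measured pair in this set differs in one place, so there is no directly comparable step to lean on. Given that the change is only a rearrangement of fluorine atoms on one ring, compound 4 is expected to land close to compound 3, and the step of a number 6 percentage points higher from compound 3 to compound 4 (within the scatter) is estimated to stay within the scatter. The estimate for compound 4 in this assay is 15%, with a range from 2% to 40%.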

Compound 4, a percentage reported as inhibition, in the whole organism at one dose (the size of the read-out at that dose, not a potency): 55%
Beside the measured number, compound 4's estimate is 40 percentage points below it; measured number above the stated range.
By their numbers in this assay, from the lowest: compound 3; then compounds 1 and 4 (each within the scatter of the next); then compound 2.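

In this assay, for the compounds shown here, the rearrangement of fluorine atoms on the outer ring gives a number 46 percentage points higher from compound 3 to compound 4 (beyond the scatter), the only comparison in this set where a single part of the structure differs. It shows that, at this place on the chain, the outcome depends on where the fluorine atoms sit and not merely on their presence, since 2,3,4,5-tetrafluorophenyl and 2,3,5,6-tetrafluorophenyl have the same atoms, no hydrogen-bond donors or acceptors and no net charge. Nothing available here accounts for why the pattern of substitution matters so much in the whole animal.

On these data alone, it remains open whether a phenyl ring with no fluorine, or a pentafluorophenyl group, at the same place would read closer to compound 3 or to compound 4, which would help show how the effect depends on the ring's substitution. Also unresolved is whether the same exchange of fluorine patterns would give a comparable step on the core of compound 1 or with the alkyne linker of compound 2, and whether the step would persist at other doses.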